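Shortening the alkyl chain on the shared core

The compounds below may be only part of what the source reports. "The series", "measured", "known", "first", "only" and "open" are said of these compounds alone.

Among the measured compounds shown here, compound 1 `CCCCCCc1[nH]c2cc(OC)ccc2c1C(=O)c1cc(OC)c(OC)c(OC)c1` gives 37.8 nM in a functional assay on KB cells (Homo sapiens) for inhibition (on this read-out lower numbers stand for stronger inhibition and higher numbers for weaker inhibition), the higher of the two numbers measured so far; compound 2 `CCCc1[nH]c2cc(OC)ccc2c1C(=O)c1cc(OC)c(OC)c(OC)c1` gives 11 nM. For the measured compounds named here, the one measured step, a 3.4-fold lower number from compound 1 to compound 2 (0.54 log units; beyond the scatter), moves toward a lower number as the chain is shortened. Compound 3 `CCCCCc1[nH]c2cc(OC)ccc2c1C(=O)c1cc(OC)c(OC)c(OC)c1` differs from compound 1 by hydrogen in place of methyl on a saturated chain carbon, five bonds along the chain from an aromatic carbon. This trims the same chain by a single carbon, so a smaller move in the same direction is expected. Compound 3 is expected to give 25 nM in this assay, with a range of 12 nM to 55 nM. The expected step is a 1.5-fold lower number from compound 1 to compound 3 (0.18 log units; within the scatter).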

Compound 3, half-maximal inhibitory concentration: 38 nM
Beside the measured number, compound 3's estimate is 1.5-fold (0.18 log units) below it, within the range that was stated.
By their numbers in this assay, from the lowest: compound 2; then compounds 1 and 3 (each within the scatter of the next).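

At this position, a 1.0-fold higher number from compound 1 to compound 3 (0.00 log units; within the scatter) leaves the two longer chains unseparated in this assay. The step beyond the scatter is instead a 3.5-fold higher number from compound 2 to compound 3 (0.54 log units; beyond the scatter), so among these three compounds the difference does not spread evenly along the chain: it lies between compound 2 and compound 3, and none lies between compound 3 and compound 1. No measured evidence here accounts for this result.

Open, on these data alone, are chains shorter than that of compound 2, such as ethyl or methyl, and chains longer than that of compound 1. Also open, as far as these compounds go, is how a chain ending in an amine or a hydroxyl would read.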